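The compounds below may be only part of what the source reports. "The series", "measured", "known", "first", "only" and "open" are said of these compounds alone.

Of the compounds shown here, two have been measured in an assay on microsomes for inhibition of acyl-CoA desaturase 1 (Mus musculus), with a stated time of 60 min; on this read-out lower numbers stand for stronger inhibition and higher numbers for weaker inhibition. Compound 1, `Cc1ccc(C(=O)Nc2ncc(Cc3cccc(C(F)(F)F)c3)s2)cc1C`, carries a trifluoromethyl group on its benzyl ring and a dimethylbenzamide; in this assay compound 1 gives 8220 nM. Compound 2, `COc1ccc(C(=O)Nc2ncc(Cc3cccc(F)c3)s2)cc1OCCO`, has a single fluoro group on the benzyl ring and a different amide; in this assay compound 2 gives 2 nM, the lower of the two numbers, and the gap to compound 1 lies well beyond the usual scatter.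

Compound 3, `COc1ccc(C(=O)Nc2ncc(Cc3cc(F)cc(F)c3)s2)cc1OCCO`, has not yet been measured. It differs from compound 2 by fluoro in place of hydrogen on an aromatic carbon. For the measured compounds named here, since the two measured compounds differ in several places at once, no measured pair isolates a change of this kind, so there is no direct precedent to lean on.

A single added fluoro group on an aromatic ring is a small change, and the expectation is a small step from compound 2 to compound 3 in this assay, either none beyond the scatter or a modest move towards a higher number, as a 1.5-fold higher number from compound 2 to compound 3 (0.18 log units; within the scatter). Compound 3 is therefore expected to give about 3 nM, plausibly between 1 nM and 10 nM.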

Compound 3, half-maximal inhibitory concentration: 0.1 nM
The estimate for compound 3 lay 30-fold (1.48 log units) above the measured number; measured number below the stated range.
By their numbers in this assay, from the lowest: compound 3; then compound 2; then compound 1.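

In this assay, for the compounds shown here, the change from 3-fluorobenzyl to 3,5-difluorobenzyl gives a 20-fold lower number from compound 2 to compound 3 (1.30 log units; beyond the scatter), and this is the first measured pair that differs in one place only. It shows that this position, on an aromatic carbon meta to a fluoro group and meta to a large group, responds strongly to a single added fluoro group, even though compound 2 already stands at a low number. Nothing measured on these compounds speaks to the reason for this step, which stays unknown.

The compounds shown carry only hydrogen or fluoro at this position, so it remains open whether a chloro group, a methoxy group or a nitrile there would give a similar number, or whether the step belongs to fluoro alone. On these data alone, compound 1 differs from the others in several places at once, so the separate contributions of its trifluoromethyl group and its dimethylbenzamide cannot be read, and whether a second fluoro group would give a similar step with a different amide also stays open.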